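Adding a chloro on the phenyl ring of compound 2

The compounds below may be only part of what the source reports. "The series", "measured", "known", "first", "only" and "open" are said of these compounds alone.

Measured so far:
compound 1 `COc1cccc(/C=C/C(=O)c2c(OC)cc(OC)cc2OC)c1` — 40%
compound 2 `COc1cc(OC)c(C(=O)/C=C/c2ccccc2)c(OC)c1` — 45%

In a functional assay on Huh-7 cells (Homo sapiens), read by fluorescence and BrdU incorporation, with a stated time of 48 h, tested at 10 uM (on this read-out higher numbers stand for a weaker effect at the one concentration tested and lower numbers for a stronger effect), compound 1 gives 40% and compound 2 gives 45%. Compound 2 stands highest of the two numbers, with compound 1 nearest; the step of a number 5 percentage points higher from compound 1 to compound 2 (within the scatter) lies within the scatter, so the two cannot be ranked. Compound 3 `COc1cc(OC)c(C(=O)/C=C/c2ccc(Cl)cc2)c(OC)c1` differs from compound 2 by chloro in place of hydrogen on an aromatic carbon. Among the measured compounds shown here, no measured step concerns a chloro; the only step on record, a number 5 percentage points higher from compound 1 to compound 2 (within the scatter), was small and bore on another change, so little movement is expected: a number 3 percentage points lower from compound 2 to compound 3 (within the scatter). Compound 3 is therefore estimated at 42%, between 20% and 65%.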

Compound 3, a percentage reported as activity, at one concentration (the size of the read-out at that concentration, not a potency): 33%
Beside the measured number, compound 3's estimate is 9 percentage points above it; measured number inside the range.
By their numbers in this assay, from the lowest: compounds 3, 1 and 2 (each within the scatter of the next, the first and the last beyond it).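

In this assay, among the compounds shown here, the change from phenyl to 4-chlorophenyl gives a number 12 percentage points lower from compound 2 to compound 3 (beyond the scatter) and is the first step here to clear the usual scatter, so a substituent at this ring position can alter the effect. Chloro is thus tied to a stronger effect than hydrogen here, yet the comparison with the 3-methoxyphenyl group gives a number 7 percentage points lower from compound 1 to compound 3 (within the scatter) and so does not rank those two compounds. Nothing available explains the step.

As far as these compounds go, whether this is particular to chloro stays open, as fluoro, methyl or an amine at the same place would show.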